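The compounds below may be only part of what the source reports. "The series", "measured", "known", "first", "only" and "open" are said of these compounds alone.

Of the compounds shown here, two with the same core have been tested. Compound 1 `CC1=C(/C=C/C(=O)/C=C/c2cccc(C(F)(F)F)c2)C(C)(C)CCC1O` gives 740 nM in a functional assay on LNCaP cells (Homo sapiens) for cytotoxicity, read by MTT assay, with a stated time of 72 h; on this read-out higher numbers stand for weaker inhibition and lower numbers for stronger inhibition. Compound 2 `CC1=C(/C=C/C(=O)/C=C/c2ccc(F)cc2)C(C)(C)CCC1O` gives 3900 nM in this assay, the highest of the two numbers and well beyond the scatter from compound 1. Compound 3 `CC1=C(/C=C/C(=O)/C=C/c2ccc(F)c(C(F)(F)F)c2)C(C)(C)CCC1O` is not yet measured; it differs from compound 2 by trifluoromethyl in place of hydrogen on an aromatic carbon, so it carries the trifluoromethyl group that compound 1 also carries. A step downward is expected, roughly a 3.9-fold lower number from compound 2 to compound 3 (0.59 log units; beyond the scatter), because compound 1 gives 740 nM. For compound 3 the estimate is 1000 nM, expected to fall between 350 nM and 2800 nM.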

Compound 3, half-maximal inhibitory concentration: 2200 nM
Compound 3: middle estimate off by 2.2-fold (0.34 log units), on the low side, and the stated range covers the measured number.
By their numbers in this assay, from the lowest: compound 1; then compounds 3 and 2 (each within the scatter of the next).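

In this assay, trifluoromethyl in place of hydrogen on this aromatic carbon, ortho to a fluoro group, gives a 1.8-fold lower number from compound 2 to compound 3 (0.25 log units; within the scatter), so no real effect can be claimed for this change. Fluoro in place of hydrogen, by contrast, gives a 3.0-fold higher number from compound 1 to compound 3 (0.47 log units; beyond the scatter), so the low number of compound 1 does not carry over to compound 3. Nothing measured here explains this difference.

Still open, going by these compounds, is how an amine or a methoxy group on this carbon would compare with hydrogen. Also open, on these data alone, is how a ring carrying neither fluoro nor trifluoromethyl would read.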